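From Vinyl to Hydrogen on the Shared Core

The source may hold more compounds than are shown below. What is called first, only, known or untested is meant among the compounds shown, and "the series" means these compounds.

For the measured compounds named here, in a functional assay on HL-60 cells (Homo sapiens) for inhibition, read by resazurin assay, with a stated time of 72 h (a higher number here means a weaker inhibitor, a lower number a stronger inhibitor), compound 3 `C=CC1C(=O)N(c2cc(OC)c(OC)c(OC)c2)C1c1ccc(OCC)cc1` gives 35 nM, the second highest of the three numbers measured so far. Compound 1 `CCOc1ccc(C2C(O)C(=O)N2c2cc(OC)c(OC)c(OC)c2)cc1`, which carries hydroxy on the same ring carbon, gives 11 nM, and compound 2 `COc1ccc(C2CC(=O)N2c2cc(OC)c(OC)c(OC)c2)cc1` gives 76 nM. The next structure, compound 4 `CCOc1ccc(C2CC(=O)N2c2cc(OC)c(OC)c(OC)c2)cc1`, has hydrogen in place of vinyl on a saturated ring carbon.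

Going by the values given here, only one measured step touches that ring carbon: a 3.2-fold higher number from compound 1 to compound 3 (0.50 log units; beyond the scatter), a modest step for vinyl in place of hydroxy. It does not show what hydrogen does there. The closer guide is compound 2, which already has hydrogen on that carbon and carries methoxy where compound 4 has ethoxy. With compound 2 at 76 nM, a modest step toward a higher number is expected in this assay, and so a somewhat weaker inhibitor. Among the compounds with values here, no measured pair isolates methoxy against ethoxy, so the expectation stays broad. The step is estimated as a 2.0-fold higher number from compound 3 to compound 4 (0.30 log units; within the scatter). Compound 4 is expected at about 70 nM, with an estimated range from 25 nM to 200 nM.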

Compound 4, half-maximal inhibitory concentration: 88 nM
The estimate for compound 4 lay 1.3-fold (0.10 log units) below the measured number; low and high end bracket the measured number.
By their numbers in this assay, from the lowest: compound 1; then compound 3; then compounds 2 and 4 (each within the scatter of the next).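

Compound 4 gives the shared core its first reading with hydrogen on this saturated ring carbon in this assay, and both other groups compare favourably with it: vinyl gives way to hydrogen with a 2.5-fold higher number from compound 3 to compound 4 (0.40 log units; beyond the scatter) and hydroxy gives way to hydrogen with an 8.0-fold higher number from compound 1 to compound 4 (0.90 log units; beyond the scatter) as the larger step. Among these three compounds the numbers therefore rise from hydroxy through vinyl to hydrogen, so this ring carbon tolerates either group and gives a lower number with each than with hydrogen, while the ethoxy chain offers no such separation, since the only measured pair for it, with a 1.2-fold higher number from compound 2 to compound 4 (0.06 log units; within the scatter), lies within the scatter and leaves compound 2 and compound 4 indistinguishable. Nothing in the information available explains why the groups on the ring carbon fall in this order.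

Still open, from the compounds shown here alone, is whether an amine, a methyl or an ethyl on this ring carbon would fall with hydroxy, with vinyl or with hydrogen. Also open, going by these compounds, is whether a longer chain such as propoxy in place of ethoxy would stay within the scatter of these two compounds, and whether methoxy and ethoxy would still match with hydroxy or vinyl on the ring carbon.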